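Trading a Carbamate Side Chain for a Hydroxy Ether

A few compounds are considered here, and "the series" means these few. Any claim that something is new, unique, unknown or untested is made for them only; others in the source may bear on it.

Measured compounds:
compound 1, `CC1=C(N2CC2)C(=O)C(CCCOC(N)=O)=C(N2CC2)C1=O`, gives 6.18;
compound 2, `CCOC(COC(N)=O)C1=C(N2CC2)C(=O)C(C)=C(N2CC2)C1=O`, gives 6.18;
compound 3, `CC1=C(N2CC2)C(=O)C(CCCc2ccccc2)=C(N2CC2)C1=O`, gives 4.47.

All three were tested in a functional assay on L1210 cells (Mus musculus), with a stated time of 12 days; a lower number here means a less potent compound, a higher number a more potent compound, by a factor of ten per unit of this negative logarithm. Compound 1 stands level with compound 2 at the digits printed, and these two share the highest numbers of the three; compound 3 lies far below, with a number 1.71 log units lower from compound 1 to compound 3 (beyond the scatter). That single step is the only one that bears on the question here, and it is large.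

Compound 4, `COC(CO)C1=C(N2CC2)C(=O)C(C)=C(N2CC2)C1=O`, has not yet been measured. It differs from compound 1 as follows: a group of 5 heavy atoms (3 carbon, 2 oxygen; no ring) in place of a group of 7 heavy atoms (4 carbon, 1 nitrogen, 2 oxygen; no ring), on a double-bonded ring carbon. The group that leaves carries the carbamoyloxy end of the chain of compound 1; the group that enters, 2-hydroxy-1-methoxyethyl, keeps one hydrogen-bond donor and two acceptors but is shorter.

Going by the values given here, the one relevant step shows that removing the carbamoyloxy group in favour of a phenyl cost a great deal, so some loss is expected for compound 4 as well, though the retained donor and acceptors argue for a smaller step than from compound 1 to compound 3. For compound 4 a step of a number 0.58 log units lower from compound 1 to compound 4 (beyond the scatter) is therefore expected. The estimate for compound 4 in this assay is 5.6, within 4.9 to 6.3.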

Compound 4, logarithm of the reciprocal of the active concentration, log(1/C): 6.9
Estimate against measurement, compound 4: 1.30 log units below; the whole stated range lies below it.
By their numbers in this assay, from the lowest: compound 3; then compounds 1 and 2 (each within the scatter of the next); then compound 4.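

The carbamoyloxy end of the chain in compound 1 turns out not to be needed for a high number at this double-bonded ring carbon: in this assay, replacing the whole group with the shorter 2-hydroxy-1-methoxyethyl gives a number 0.72 log units higher from compound 1 to compound 4 (beyond the scatter). The earlier step, a number 1.71 log units lower from compound 1 to compound 3 (beyond the scatter), could be read as a penalty for losing the carbamoyloxy group, but the new result shows that this loss can be more than made good by a different group, so what sits on this carbon can raise the number as well as lower it. The leaving and entering groups have the same counts of hydrogen-bond donors and acceptors, but no measurement here explains why the number rises.

Still open, going by these compounds, is which feature of 2-hydroxy-1-methoxyethyl matters, since the hydroxy group, the methoxy group and the shorter length all change together with the loss of the carbamoyloxy group. A primary amine or a carboxylic acid in place of the hydroxy group, or a plain 2-hydroxyethyl chain without the methoxy group, would help to separate these parts.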